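A Chlorophenyl Swap on the Amide Nitrogen

This account rests on a few compounds, and the source may have more. Where it says the series, first, only, none or still open, it means among the compounds named here.

In an ADME assay on BHK-21 cells (Mesocricetus auratus) for cytotoxicity, with a stated time of 3 days (on this read-out lower numbers stand for higher toxicity in this test and higher numbers for lower toxicity in this test), compound 1 `O=C(CSc1nnc(-c2ccncc2)s1)Nc1ccc(Cl)cc1` gives only a limit, > 50000 nM. Compound 3 `CC(Sc1nnc(-c2ccncc2)s1)C(=O)Nc1ccc(Cl)cc1` likewise gives only a limit in this assay, > 50000 nM. Compound 2 `O=C(CCSc1nnc(-c2ccncc2)s1)NCc1ccccc1` gives a number in this assay, 18700 nM. Among the measured compounds shown here, the single step between compounds that differ in one place, a step that the two limits leave unreadable from compound 1 to compound 3, therefore cannot be sized. Both limits fall at the limit of > 50000 nM in this assay, at which 2 of the 3 values shown sit, so this part of the series shows low toxicity on the read-out.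

Compound 4 `O=C(CSc1nnc(-c2ccncc2)s1)Nc1ccccc1Cl` has not yet been measured. It differs from compound 1 in one place: 2-chlorophenyl in place of 4-chlorophenyl on an amide-type nitrogen. For the measured compounds named here, no measured step changes the same group, so no step bears directly on this change. Going by the values given here, the one measured step, on the saturated chain carbon, is unreadable, and compound 2 differs from compound 1 in more than one place, so its value can only be set beside that of compound 1 without a readable step. With two of three values at the limit, the expectation is for no change beyond the scatter, and the step of a number no higher from compound 1 to compound 4 (the limit leaves the size open) is expected to be small. The estimate for compound 4 is 50000 nM, with a range from 15000 nM to 200000 nM.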

Compound 4, half-maximal cytotoxic concentration: > 50000 nM
Compound 4: no number, only a limit (the forecaster's own chance of this, stated with the estimate: 60%); the middle value lies on the limit itself.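

In this assay compound 4 gives only a limit, as compound 1 does, so no step can be read between them for 2-chlorophenyl in place of 4-chlorophenyl. The compounds shown leave open whether the two chlorophenyl amides differ in toxicity at all, since most values here sit at one limit: the limit of > 50000 nM in this assay, at which 3 of the 4 values shown sit.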